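The compounds below may be only part of what the source reports. "The series", "measured", "known", "first", "only" and "open" are said of these compounds alone.

Measured compounds:
- compound 1 `Cc1ccc(NC2=CC(=O)c3nc4n(c3C2=O)[C@H]2OC[C@@H](O)[C@H]2OC4)cc1C`: 860 nM
- compound 2 `CCOc1ccccc1NC1=CC(=O)c2c(nc3n2[C@H]2OC[C@@H](O)[C@H]2OC3)C1=O`: 2830 nM
- compound 3 `O=C1C(N2CCC2)=CC(=O)c2c1nc1n2[C@H]2OC[C@@H](O)[C@H]2OC1`: > 16000 nM

All three share one core and were tested in a functional assay on MGC-803 cells (Homo sapiens) for inhibition, read by sulforhodamine B assay; on this read-out higher numbers stand for weaker inhibition and lower numbers for stronger inhibition. Compound 1 gives the lower of the two measured numbers, 860 nM. Compound 2, which carries a different substituted phenylamino group on the same core, gives 2830 nM, and the gap between compound 1 and compound 2 lies beyond the usual scatter of this assay. Compound 3 carries a small saturated cyclic amine instead of an arylamino group and gives only a limit, > 16000 nM; this is the limit of > 16000 nM in this assay, at which 1 of the 3 values shown sits, not a measured number.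

The step now considered leads from compound 1 to compound 4 `O=C1C=C(N2CCCC2)C(=O)c2c1nc1n2[C@H]2OC[C@@H](O)[C@H]2OC1`. The change is pyrrolidin-1-yl in place of (3,4-dimethylphenyl)amino on a double-bonded ring carbon. Compound 4 thus ends up with a saturated cyclic amine on the double-bonded ring carbon, as compound 3 does, rather than an arylamino group as in compounds 1 and 2. The step from compound 1 to compound 4 is expected to be large and toward weaker inhibition, a 17-fold higher number from compound 1 to compound 4 (1.24 log units; beyond the scatter), because compound 3 reached only > 16000 nM. Compound 4 is estimated to give 15000 nM, within a range from 5000 nM to 40000 nM, and it may well return only a limit.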

Compound 4, half-maximal inhibitory concentration: > 16000 nM
Compound 4 gave a limit, no number; the forecaster's own chance of this, stated with the estimate: 55%; middle value at least 1.0-fold (0.02 log units) away from the limit.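

Swapping (3,4-dimethylphenyl)amino for pyrrolidin-1-yl on the double-bonded ring carbon gives the first step that can be read at this position on a single core, an at least 18-fold higher number from compound 1 to compound 4 (1.26 log units; beyond the scatter). In this assay compound 4 gives > 16000 nM, which is a limit and not a number, so this step has a lower bound but no exact size. Compound 4 also joins compound 3 at the top of the measurable range, which shows that a second saturated cyclic amine ends up at the same limit, although the two compounds differ in more than one place and cannot be compared directly: the limit of > 16000 nM in this assay, at which 2 of the 4 values shown sit.

This single step removes the aromatic ring and the hydrogen-bond donor together, so the compounds shown cannot tell which of the two losses matters, or whether both do. Cyclohexylamino would keep the donor on a non-aromatic ring, and N-methyl-N-phenylamino would keep the aromatic ring without the donor, so this pair of groups could pull the two changes apart on the core of compound 1.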